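The source may hold more compounds than are shown below. What is called first, only, known or untested is meant among the compounds shown, and "the series" means these compounds.

Compound 1 `CCCCC(O)CC(=O)O[C@H](CC=C(C)C)C1=CC(=O)c2c(O)ccc(O)c2C1=O` and compound 2 `CCC(CO[C@H](CC=C(C)C)C1=CC(=O)c2c(O)ccc(O)c2C1=O)OC(C)=O` share a core and differ only in the side chain on an oxygen on a saturated carbon. In a functional assay on HeLa cells (Homo sapiens) for cytotoxicity, read by MTT assay (on this read-out lower numbers stand for stronger inhibition and higher numbers for weaker inhibition), compound 1 gives 72200 nM, and compound 2 gives 44000 nM. The step of a 1.6-fold lower number from compound 1 to compound 2 (0.22 log units; within the scatter) is within the scatter, so compound 2 stands apart from compound 1 by no more than repeated measurements would. Compound 3 `CCC(C)(O)CC(=O)O[C@H](CC=C(C)C)C1=CC(=O)c2c(O)ccc(O)c2C1=O` differs from compound 2 by (2-hydroxy-2-methylbutyl)carbonyl in place of 2-acetoxybutyl on an oxygen on a saturated carbon, and the group that enters is close to the (2-hydroxyhexyl)carbonyl of compound 1 apart from its branching and length. For the measured compounds named here, the one step that bears on this change, a 1.6-fold lower number from compound 1 to compound 2 (0.22 log units; within the scatter), was within the scatter, so for compound 3 no step beyond the scatter is expected in this assay, with the number expected to fall between those of compound 1 and compound 2. The estimate for compound 3 is therefore 58000 nM, between 25000 nM and 140000 nM, meaning an expected step of a 1.3-fold higher number from compound 2 to compound 3 (0.12 log units; within the scatter).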

Compound 3, half-maximal inhibitory concentration: 25200 nM
Beside the measured number, compound 3's estimate is 2.3-fold (0.36 log units) above it; the range from low to high includes it.
By their numbers in this assay, from the lowest: compounds 3, 2 and 1 (each within the scatter of the next, the first and the last beyond it).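

In this assay the side chain now gives its first step beyond the scatter: on a saturated chain carbon bound to a carbonyl carbon, 1-hydroxy-1-methylpropyl in place of 1-hydroxypentyl gives a 2.9-fold lower number from compound 1 to compound 3 (0.46 log units; beyond the scatter), a modest change. By contrast, (2-hydroxy-2-methylbutyl)carbonyl in place of 2-acetoxybutyl on an oxygen on a saturated carbon gives a 1.7-fold lower number from compound 2 to compound 3 (0.24 log units; within the scatter), which lies within the scatter, so these two side chains are not told apart here. No measurement shown accounts for either step.

The compounds shown leave open whether the lower number goes with the shorter chain or with the branching: the two change together in 1-hydroxy-1-methylpropyl, and a 1-hydroxypropyl group would separate them. Also open, as far as these compounds go, is whether the hydroxyl itself matters, which an amine or a methoxy group in its place would test.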